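The source may hold more compounds than are shown below. What is called first, only, known or untested is meant among the compounds shown, and "the series" means these compounds.

Working notes on the series, read in a functional assay on MT4 cells (Homo sapiens) for inhibition; on this read-out lower numbers stand for stronger inhibition and higher numbers for weaker inhibition. Compound 1 `C=C1[C@@H](O)[C@H](n2ccc(N)nc2=O)O[C@@H]1CO` gives 121000 nM, and compound 2 `C=C1C(n2ccc(N)nc2=O)O[C@H](CO)[C@@H]1O` gives 190 nM. Compound 3 `C=C1[C@@H](O)[C@H](n2cnc3c(Cl)nc(N)nc32)O[C@@H]1CO` reads > 500000 nM, which is a limit of the assay and not a number. Compound 3 therefore offers no exact starting value.

Compound 4 `C=C1[C@@H](O)[C@H](n2cnc3c(S)nc(N)nc32)O[C@@H]1CO` keeps the rest of compound 3 and has sulfanyl in place of chloro on an aromatic carbon. Within the data shown here, no measured pair isolates this change, so its size in this assay can only be expected. A modest move toward stronger inhibition is expected, with inhibition staying weak. The closest measured number is that of compound 1 at 121000 nM, and a value near that of compound 2 at 190 nM is not expected. The estimated change is an at least 3.3-fold lower number from compound 3 to compound 4 (0.52 log units; beyond the scatter). For compound 4 the estimated value is 150000 nM, with an expected range of 10000 nM to 500000 nM.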

Compound 4, half-maximal inhibitory concentration: 12000 nM
Estimate against measurement, compound 4: 13-fold (1.10 log units) above, and the stated range covers the measured number.
By their numbers in this assay, from the lowest: compound 2; then compound 4; then compound 1. At a limit, above all of these: compound 3.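

In this assay, among these compounds, the aromatic carbon opposite the ring nitrogen turns out to be sensitive to a single-atom exchange: sulfanyl in place of chloro gives the only step that isolates a change at this place (an at least 41-fold lower number from compound 3 to compound 4 (1.61 log units; beyond the scatter)). Compound 3 stands at a limit and not at a number, so this step fixes only a minimum size: the limit of > 500000 nM in this assay, at which 1 of the 4 values shown sits. The exchange of one heavy atom, which also brings in 1 hydrogen-bond donor and 1 hydrogen-bond acceptor, is enough for compound 4 to give a measured value of 12000 nM on the shared core.

From the compounds shown here alone, whether this shift belongs to sulfanyl itself or would follow any replacement of chloro stays open, and hydroxyl, methoxy or methylsulfanyl at this carbon would separate the two readings. Compounds 1 and 2 differ from compound 4 in more than one place, so they give no second reading of this change.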